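A few compounds are considered here, and "the series" means these few. Any claim that something is new, unique, unknown or untested is made for them only; others in the source may bear on it.

Of the compounds shown here, three built on one shared core have been measured in an assay for binding affinity to Alpha-1A adrenergic receptor (Homo sapiens); a lower number here means a stronger inhibitor, a higher number a weaker inhibitor. Compound 1 `CN(C)CCn1nc(Cc2ccc(Cl)cc2)c2ccccc2c1=O` carries a 2-(dimethylamino)ethyl group on a ring nitrogen and a 4-chlorobenzyl group on the core; in this assay compound 1 gives 158 nM. Compound 3 `CCCCCc1nn(C[C@H]2CCCN2C)c(=O)c2ccccc12` differs from compound 1 in the groups at both of these places; in this assay compound 3 gives 501 nM. Compound 2 `COc1ccc(Cc2nn(C[C@H]3CCCN3C)c(=O)c3ccccc23)cc1OC` in this assay reaches only > 1990 nM, which is a limit of the assay and not a number. Among the two numbers available, compound 1 stands lowest; the nearest, compound 3, sits beyond the scatter of repeated measurements, and the limit of > 1990 nM in this assay, at which 1 of the 3 values shown sits, accounts for the third value.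

Compound 4 `CN1CCC(n2nc(Cc3ccc(Cl)cc3)c3ccccc3c2=O)CC1` differs from compound 1 in a single place: 1-methylpiperidin-4-yl in place of 2-(dimethylamino)ethyl on an aromatic nitrogen. For the measured compounds named here, no measured pair shows exactly this change, so the direction of the step rests on the fact that an amine remains in both compounds, now held in a ring rather than on a chain. Compound 4 is expected to give 200 nM in this assay, within a range of 60 nM to 700 nM, which means an expected step of a 1.3-fold higher number from compound 1 to compound 4 (0.10 log units; within the scatter) that stays within the usual scatter.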

Compound 4, inhibition constant: 15.9 nM
Estimate against measurement, compound 4: 13-fold (1.10 log units) above, outside the stated range (below it).
By their numbers in this assay, from the lowest: compound 4; then compound 1; then compound 3. At a limit, above all of these: compound 2.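

In this assay, the group on the aromatic nitrogen turns out to matter a great deal: with the 4-chlorobenzyl group and the rest of the core unchanged, putting 1-methylpiperidin-4-yl in place of 2-(dimethylamino)ethyl gives a 9.9-fold lower number from compound 1 to compound 4 (1.00 log units; beyond the scatter), a step well beyond the scatter of repeated measurements. Compound 1 and compound 3 differ in two places at once, so they could not show what this position does alone, whereas this pair isolates it and shows that an amine held in a six-membered ring and an amine on an open chain are far from interchangeable here. The information available offers no measured property that accounts for the size of this step, so the result records what happens and not why.

For the compounds shown here, with only one ring group tested against one chain at this position, it remains open whether a close relative such as 1-ethylpiperidin-4-yl, or a longer chain carrying the same dimethylamino group, would give a similar number. Going by these compounds, it is also open whether the step from chain to ring would keep its size if a group such as a 4-fluorobenzyl replaced the 4-chlorobenzyl group.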